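Swapping a pyridine ring for a dimethylaminophenyl ring

The source may hold more compounds than are shown below. What is called first, only, known or untested is meant among the compounds shown, and "the series" means these compounds.

Compound 3 `Cc1cc(NCc2ccccn2)n2ncc(-c3ccncc3)c2n1` is the starting point here. In a physicochemical assay for solubility, read by HPLC, using the shake flask method, measured as kinetic solubility, with a stated time of 2 h, at pH 7.4 (on this read-out lower numbers stand for lower solubility and higher numbers for higher solubility), compound 3 gives 161000 nM, the highest of the two plain numbers shown. Its nearest neighbour is compound 1 `Cc1cc(NCc2ccccn2)n2ncc(Br)c2n1`, which in this assay gives 89300 nM; a 1.8-fold higher number from compound 1 to compound 3 (0.26 log units; within the scatter) is within the scatter, so the two cannot be ranked against each other. Compound 2 `Cc1cc(NCc2ccccn2)n2ncc(-c3ccc(N(C)C)cc3)c2n1` differs from compound 3 only in the group attached to the shared core. For compound 2 this assay reports only a limit, < 5000 nM, rather than a number (the limit of < 5000 nM in this assay, at which 1 of the 3 values shown sits).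

Compound 4 `Cc1cc(NCc2ccccn2)n2ncc(-c3cccc(N(C)C)c3)c2n1` has not yet been measured. It differs from compound 3 in one place: 3-(dimethylamino)phenyl in place of pyridin-4-yl on an aromatic carbon. Among the compounds with values here, two measured steps bear on this change. The an at least 32-fold higher number from compound 2 to compound 3 (1.50 log units; beyond the scatter) shows that replacing the dimethylaminophenyl group by the pyridinyl group came with a large rise, and an at least 17-fold lower number from compound 1 to compound 2 (1.25 log units; beyond the scatter) shows that putting the dimethylaminophenyl group in place of bromo came with a large fall. Compound 4 carries a dimethylaminophenyl group too, the 3-substituted rather than the 4-substituted one, so a large fall is expected: a 20-fold lower number from compound 3 to compound 4 (1.30 log units; beyond the scatter). Compound 4 is therefore estimated at 8000 nM, with a likely range from 2000 nM to 40000 nM.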

Compound 4, solubility: 94600 nM
Compound 4: the middle estimate sits 12-fold (1.07 log units) below what was measured; the measured number lies above the stated range.
By their numbers in this assay, from the lowest: compounds 1, 4 and 3 (each within the scatter of the next). At a limit, below all of these: compound 2.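

Compound 4 shows that the large fall seen earlier does not come with every dimethylaminophenyl group on this aromatic carbon of the five-membered ring. In this assay, putting 3-(dimethylamino)phenyl in place of 4-(dimethylamino)phenyl gives an at least 18-fold higher number from compound 2 to compound 4 (1.27 log units; beyond the scatter), so where the dimethylamino group sits on the phenyl ring makes a large difference to the read-out. The 3-substituted group also stays level with the two smaller groups, as a 1.7-fold lower number from compound 3 to compound 4 (0.23 log units; within the scatter) and a 1.1-fold higher number from compound 1 to compound 4 (0.03 log units; within the scatter) both lie within the scatter, so compounds 1, 3 and 4 cannot be ranked against one another. Compound 2 remains the one compound read at a limit rather than a number, so the step to compound 4 gives only a lower bound on its size: the limit of < 5000 nM in this assay, at which 1 of the 4 values shown sits.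

Going by these compounds, what a primary amine or a carboxylic acid would do in place of the dimethylamino group on the same phenyl ring stays open. The compounds also offer no measured property that would explain the gap between the two dimethylaminophenyl groups.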